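Methoxy pattern on the cinnamate ring; effect of 2-methoxyphenyl

This account rests on a few compounds, and the source may have more. Where it says the series, first, only, none or still open, it means among the compounds named here.

Measured so far:
compound 1 `COc1cc(OC)c(OC)cc1/C=C/COC(=O)/C=C/c1ccc(OC)c(OC)c1OC`, 100%
compound 2 `COc1cc(OC)c(OC)cc1/C=C/COC(=O)/C=C/c1ccc(OC)c(OC)c1`, 100%

Both values come from a functional assay on the whole organism (strain Kunming) with Mus musculus as the target, with a stated time of 0.5 h, at a dose of 100 mg/kg by the intraperitoneal route; a lower number here means a stronger effect, a higher number a weaker effect of the compound at the dose given. The step of no change at the digits printed from compound 1 to compound 2 (within the scatter) shows that removing one methoxy from the cinnamate ring left the read-out where it was. Compound 2 therefore stands level with compound 1, with no step beyond the scatter.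

Compound 3 `COc1ccccc1/C=C/C(=O)OC/C=C/c1cc(OC)c(OC)cc1OC` differs from compound 2 by 2-methoxyphenyl in place of 3,4-dimethoxyphenyl on a double-bonded chain carbon bound to a double-bonded chain carbon. Among the measured compounds shown here, only the step from compound 1 to compound 2 bears on this change, and it was flat, so no step beyond the scatter is expected, no change at the digits printed from compound 2 to compound 3 (within the scatter). Compound 3 is estimated at 100%, range 80% to 100%.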

Compound 3, a percentage reported as activity, at one dose (the size of the read-out at that dose, not a potency): 100%
Compound 3: the middle estimate sits on the measured number at the digits printed; measured number inside the range.
By their numbers in this assay, from the lowest: compounds 1, 2 and 3 (each within the scatter of the next).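

Replacing 3,4-dimethoxyphenyl with 2-methoxyphenyl on a double-bonded chain carbon bound to a double-bonded chain carbon gives (no change at the digits printed from compound 2 to compound 3 (within the scatter)) in this assay. The earlier step removed a single methoxy, whereas this one exchanges the whole aryl group and the read-out still holds, so this position has now taken a larger change without a step beyond the scatter. No measurement on hand explains this flat result.

From the compounds shown here alone, whether any group at this position can move the read-out remains open. An amine or a carboxylic acid on this ring in place of methoxy would test that.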